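A few compounds are considered here, and "the series" means these few. Any claim that something is new, unique, unknown or untested is made for them only; others in the source may bear on it.

Of the compounds shown here, three built on one shared core have been tested in a functional assay on KB cells (Homo sapiens) for inhibition, read by sulforhodamine B assay, with a stated time of 72 h; on this read-out lower numbers stand for stronger inhibition of growth and higher numbers for weaker inhibition of growth. Compound 1 `NC(=O)/C=C/c1ccncc1-c1ccc2ccccc2c1` gives only a limit there, > 10000 nM. Compound 2 `CNC(=O)/C=C/c1ccncc1-c1ccc2[nH]ccc2c1` likewise returns a limit, > 10000 nM. Compound 3 `NNC(=O)CCc1ccncc1-c1ccc2ccccc2c1` also reaches no number but a limit, > 10000 nM. Within the data shown here, the single change that connects two of these, a step that the two limits leave unreadable from compound 1 to compound 3, cannot be sized because of the limit of > 10000 nM in this assay, at which 3 of the 3 values shown sit. Compound 4 `O=C(/C=C/c1ccncc1-c1ccc2ccccc2c1)N1CCOCC1` remains to be measured; it differs from compound 1 by morpholin-4-yl in place of amino on a carbonyl carbon. Among the measured compounds shown here, no measured step bears on this change: the only step between measured compounds is unreadable, and the difference between compound 1 and compound 2 is not a single step. Compound 1 therefore stands at a limit with nothing to show a direction. Compound 4 is thus expected to stay near that limit as well, with the step that the limit leaves unreadable from compound 1 to compound 4 expected to lie within the scatter. The estimate for compound 4 is 20000 nM, expected to fall between 8000 nM and 60000 nM.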

Compound 4, concentration for 50% growth inhibition: > 10000 nM
Compound 4: only a limit was reported (the forecaster's own chance of this, stated with the estimate: 80%); the middle value is on the limit's open side.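

Compound 4, like compound 1, gives only a limit, so no size can be read for the step between them: the limit of > 10000 nM in this assay, at which 4 of the 4 values shown sit.

The compounds shown leave open which change to the shared core, if any, would give a measured number rather than a limit.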